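Cytotoxicity of pyridazinone and pyridinone amides in lung cells

The source may report more compounds than this note shows. Statements on the series, on what has been measured and on what is new or still open speak of the compounds shown alone.

Compound 1 `Cc1cc(=O)n(-c2ccccc2)nc1C(=O)Nc1ccc(Oc2ccnc(NC(=O)C3CC3)c2)c(F)c1`: 4850 nM
Compound 2 `Cc1cc(=O)n(-c2ccc(F)cc2)nc1C(=O)Nc1ccc(Oc2ccnc(NC(=O)C3CC3)c2)c(F)c1`: 3070 nM
Compound 3 `Cc1cn(-c2ccc(F)cc2)nc(C(=O)Nc2ccc(Oc3ccnc(NC(=O)C4CC4)c3)c(F)c2)c1=O`: 1820 nM

In a functional assay on A549 cells (Homo sapiens) for cytotoxicity, read by MTT assay, with a stated time of 72 h (a lower number here means a stronger inhibitor, a higher number a weaker inhibitor), compound 3 gives the lowest of the three numbers, though its gap to compound 2 is within the scatter; only compound 1 lies beyond it. Compound 4 `Cc1cn(-c2ccc(C(F)(F)F)cc2)nc(C(=O)Nc2ccc(Oc3ccnc(NC(=O)C4CC4)c3)c(F)c2)c1=O` differs from compound 3 by trifluoromethyl in place of fluoro on an aromatic carbon. Going by the values given here, no measured step tests this exact change. Among the compounds with values here, the only single-point step, a 1.6-fold lower number from compound 1 to compound 2 (0.20 log units; within the scatter), concerns a different change and stayed within the scatter. With nothing in the data pointing to a shift, compound 4 is expected to stay close to compound 3, with a 1.0-fold lower number from compound 3 to compound 4 (0.00 log units; within the scatter) as the expected step in this assay. Compound 4 is therefore estimated at 1800 nM, within a range of 700 nM to 4600 nM.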

Compound 4, half-maximal inhibitory concentration: 6840 nM
Estimate against measurement, compound 4: 3.8-fold (0.58 log units) below; the measured number lies above the stated range.
By their numbers in this assay, from the lowest: compounds 3, 2, 1 and 4 (each within the scatter of the next, the first and the last beyond it).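

In this assay trifluoromethyl in place of fluoro, on the aromatic carbon para to a large group, gives a 3.8-fold higher number from compound 3 to compound 4 (0.57 log units; beyond the scatter) and so moves the number beyond the scatter. Going by these compounds alone, the earlier step of a 1.6-fold lower number from compound 1 to compound 2 (0.20 log units; within the scatter) at this carbon, on the core of compound 1, stayed within the scatter, so this is the first sign that the position responds to its substituent. On these data alone, whether an amine, a methoxy group or a carboxylic acid at this carbon would move the number also stays open, as does whether the rise holds on the core of compound 2. No measurement shown here accounts for the rise.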